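The source may hold more compounds than are shown below. What is called first, only, known or untested is meant among the compounds shown, and "the series" means these compounds.

Working notes on the series. Compound 1 `CC(=O)CC[C@]1(C(C)=O)C(=O)O[C@@H](OC(C)=O)[C@H]1C` gives in a functional assay on MCF7 cells (Homo sapiens) for cytotoxicity, read by MTT assay (a higher number here means a weaker inhibitor, a lower number a stronger inhibitor), 6000 nM. Compound 2 `CC(=O)[C@@]1(C)C(=O)O[C@@H](OC(=O)C(C)(C)C)[C@H]1C` gives in this assay 3000 nM, and compound 3 `CC(=O)[C@@]1(C)C(=O)O[C@@H](OC(=O)c2ccccc2)[C@H]1C` gives in this assay 3000 nM. Compound 3 thus stands level with compound 2, and compound 1 also sits within the scatter of compound 3, so no ordering among the three is secure. Within the data shown here, the only single-point step measured, no change at the digits printed from compound 2 to compound 3 (within the scatter), left the number unchanged within the scatter.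

Compound 4 `CC(=O)[C@]1(C)C(=O)O[C@@H](OC(=O)c2ccccc2)[C@H]1C` differs from compound 3 as follows: the two compounds have the same atoms and bonds and differ only in configuration as drawn: 1 of 3 stereo elements differ; a stereocentre at a saturated ring carbon is drawn S in compound 3 and R in compound 4. Among the measured compounds shown here, no measured step concerns a change of configuration; the step of no change at the digits printed from compound 2 to compound 3 (within the scatter) touches only the acyl group and gives no direct guide. With nothing in the series pointing either way, the expected step is no change at the digits printed from compound 3 to compound 4 (within the scatter), a change not beyond the scatter, held with a wide range. Compound 4 is accordingly expected at 3000 nM in this assay, estimated between 1000 nM and 10000 nM.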

Compound 4, half-maximal inhibitory concentration: 8000 nM
The estimate for compound 4 lay 2.7-fold (0.43 log units) below the measured number, and the stated range covers the measured number.
By their numbers in this assay, from the lowest: compounds 2, 3, 1 and 4 (each within the scatter of the next, the first and the last beyond it).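

Going from S to R at this saturated ring carbon gives a 2.7-fold higher number from compound 3 to compound 4 (0.43 log units; beyond the scatter) in this assay, the first single-point step in the series beyond the scatter. The earlier step touched only the acyl group and showed nothing about configuration. This step can be placed on that one stereocentre alone because no other feature changes: the fact that compounds 3 and 4 differ only in the configuration as drawn. Going by these compounds, whether the same inversion gives a like step with tert-butyl in place of phenyl stays open, as does the role of the other two stereo elements. Also open, on these data alone, is what an amine or a longer chain in place of phenyl would give in either configuration.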